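The source may report more compounds than this note shows. Statements on the series, on what has been measured and on what is new or still open speak of the compounds shown alone.

Working notes on the series, read in a functional assay on MM96L cells (Homo sapiens) for antiproliferative activity; a higher number here means a weaker inhibitor, a lower number a stronger inhibitor. Compound 1 (`CN(C)c1ccc(C(=O)NC(CCCCCC(=O)NO)C(=O)NC2CCCc3ccccc32)cc1`) gives 300 nM and compound 2 (`O=C(CCCCC[C@H](NC(=O)OCc1ccccc1)C(=O)Nc1ccc(-c2ccccc2)cc1)NO`) gives 330 nM, two values within the scatter of each other. Compound 3 (`O=C(CCCCC[C@H](NC(=O)c1ccc(Br)cc1)C(=O)Nc1ccc(-c2ccccc2)cc1)NO`) gives 70 nM. Among the compounds with values here, the one measured single-place step is a 4.7-fold lower number from compound 2 to compound 3 (0.67 log units; beyond the scatter), modest and beyond the scatter. Compound 2 therefore stands level with compound 1 and on the weaker side of compound 3.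

Compound 4 (`O=C(CCCCC[C@H](NC(=O)OCc1ccccc1)C(=O)Nc1cccc2cccnc12)NO`) keeps the benzyloxy group of compound 2 on its carbonyl carbon and changes the other end, with quinolin-8-yl in place of 4-phenylphenyl on an amide-type nitrogen. Within the data shown here, no measured step touches this place. The step of a 4.7-fold lower number from compound 2 to compound 3 (0.67 log units; beyond the scatter) lies at a different place, so it gives only a rough size for what one change can do in this series, and no direction. Compound 1 differs from compound 2 in more than one place and offers no clean comparison.

From the compounds shown here alone, the expected change in this assay is therefore none beyond the scatter, though a modest move either way remains open. The expected step is a 1.1-fold higher number from compound 2 to compound 4 (0.03 log units; within the scatter). For compound 4 the estimate is 350 nM, with an expected range of 100 nM to 1200 nM.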

Compound 4, half-maximal inhibitory concentration: 43 nM
Compound 4: middle estimate off by 8.1-fold (0.91 log units), on the high side, and the stated range ends above it.
By their numbers in this assay, from the lowest: compounds 4 and 3 (each within the scatter of the next); then compounds 1 and 2 (each within the scatter of the next).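

In this assay, the place on the amide-type nitrogen is now shown to move the number on its own, with the benzyloxy group held fixed on its carbonyl carbon: a 7.7-fold lower number from compound 2 to compound 4 (0.89 log units; beyond the scatter), on quinolin-8-yl replacing 4-phenylphenyl. At least with benzyloxy on the carbonyl carbon, 4-phenylphenyl is therefore not needed for a low number, and the entering group has fewer heavy atoms than the leaving group and carries 1 hydrogen-bond acceptor where the leaving group carries 0. No measurement on hand bears on why this change lowers the number.

From the compounds shown here alone, it remains open whether this change and the change to 4-bromophenyl on the carbonyl carbon add up when quinolin-8-yl and 4-bromophenyl stand in one compound. Going by these compounds, it is also open whether the ring nitrogen of quinolin-8-yl matters in itself, which naphthalen-1-yl on the same amide-type nitrogen would address, and how far this place tolerates a different kind of group, such as an alkyl chain ending in an amine.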